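Phenyl for Fluoro on the Anilide Ring of Compound 1

A few compounds are considered here, and "the series" means these few. Any claim that something is new, unique, unknown or untested is made for them only; others in the source may bear on it.

Compound 1 `O=C(CCc1cccc2c1B(O)OC2)Nc1ccc(F)cc1` gives 650 nM in a functional assay on HCT-116 cells (Homo sapiens) for antiproliferative activity, read by MTT assay, with a stated time of 72 h (a lower number here means a stronger inhibitor, a higher number a weaker inhibitor), and among the three measured compounds its number is the highest. Compound 2 `COc1ccccc1NC(=O)CCc1cccc2c1B(O)OC2` gives 430 nM in this assay, within the usual scatter of the value of compound 1. Compound 3 `O=C(CCc1cccc2c1B(O)OC2)Nc1cccc2ccccc12` gives 200 nM in this assay, a gap from compound 1 that lies beyond the scatter. Compound 4 `O=C(CCc1cccc2c1B(O)OC2)Nc1ccc(-c2ccccc2)cc1` has not yet been measured; it differs from compound 1 in one place: phenyl in place of fluoro on an aromatic carbon. Among the compounds with values here, no measured pair shows this change. The expected step in this assay is a modest move toward a lower number, a 2.2-fold lower number from compound 1 to compound 4 (0.34 log units; beyond the scatter), because compound 3 gives 200 nM. Compound 4 is therefore expected to give about 300 nM in this assay, within a range from 120 nM to 800 nM.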

Compound 4, half-maximal inhibitory concentration: 13000 nM
Estimate against measurement, compound 4: 43-fold (1.64 log units) below; the measured number lies above the stated range.
By their numbers in this assay, from the lowest: compound 3; then compounds 2 and 1 (each within the scatter of the next); then compound 4.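

In this assay, phenyl in place of fluoro on an aromatic carbon, para to a large group, gives a 20-fold higher number from compound 1 to compound 4 (1.30 log units; beyond the scatter). Within the data shown here, this is the first step read at this position, and it shows that the group placed there can move the number strongly toward a weaker inhibitor. Nothing given here accounts for the size of this step. Going by these compounds, it remains open whether a methyl or an amine on this same carbon would stay close to compound 1 or move as compound 4 does. On these data alone, whether phenyl at another place on this ring would give a step of similar size also remains open.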